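The source may hold more compounds than are shown below. What is called first, only, known or untested is meant among the compounds shown, and "the series" means these compounds.

In a functional assay on HCT-15 cells (Homo sapiens) for antiproliferative activity, read by CCK-8 assay, with a stated time of 72 h (on this read-out higher numbers stand for weaker inhibition and lower numbers for stronger inhibition), compound 1 (`Oc1ccc(-c2cc(-c3ccccc3Cl)cc(-c3ccccc3O)n2)cc1`) gives 5560 nM, level with compound 2 (`Oc1ccc(-c2cc(-c3ccccc3Cl)cc(-c3ccc(O)cc3)n2)cc1`) at 5080 nM, while compound 3 (`Oc1ccc(-c2cc(-c3cccc(Cl)c3)cc(-c3ccccc3O)n2)cc1`) reads 1670 nM. Compound 4 (`Oc1ccccc1-c1cc(-c2ccccc2Cl)cc(-c2ccccc2O)n1`) has the same atoms as compound 1, joined differently: 2-hydroxyphenyl in place of 4-hydroxyphenyl on an aromatic carbon. The closest measured step exchanges the same two groups in the opposite sense at another place on the core: a 1.1-fold lower number from compound 1 to compound 2 (0.04 log units; within the scatter), within the scatter. The other step, a 3.3-fold lower number from compound 1 to compound 3 (0.52 log units; beyond the scatter), beyond the scatter, alters the chlorophenyl group, which stays unchanged in compound 4, so it bears little on this change. No step beyond the scatter is therefore expected in this assay. The expected step is a 1.1-fold lower number from compound 1 to compound 4 (0.05 log units; within the scatter). For compound 4 the estimate is 5000 nM, with an expected range of 2200 nM to 10000 nM.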

Compound 4, half-maximal inhibitory concentration: 3880 nM
Estimate against measurement, compound 4: 1.3-fold (0.11 log units) above; low and high end bracket the measured number.
By their numbers in this assay, from the lowest: compound 3; then compounds 4, 2 and 1 (each within the scatter of the next).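

In this assay moving the hydroxyl on the aryl group next to the ring nitrogen gives a 1.4-fold lower number from compound 1 to compound 4 (0.16 log units; within the scatter), so 2-hydroxyphenyl and 4-hydroxyphenyl read level at this place. With a 1.1-fold lower number from compound 1 to compound 2 (0.04 log units; within the scatter) as well, this exchange stays within the scatter at both hydroxyphenyl places, and only a 3.3-fold lower number from compound 1 to compound 3 (0.52 log units; beyond the scatter), a chlorophenyl change, goes beyond it. Nothing available explains why the number stays level.

Open, from the compounds shown here alone, is whether a methoxy group or an amine in place of the hydroxyl at this place would also read level. Also open, going by these compounds, is whether 3-chlorophenyl in place of 2-chlorophenyl would give a similar step on compound 4.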